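The source may hold more compounds than are shown below. What is called first, only, known or untested is meant among the compounds shown, and "the series" means these compounds.

Measured so far in a functional assay on MCF7 cells (Homo sapiens) for antiproliferative activity, read by MTT assay, with stated times of 24 h and 72 h; a lower number here means a stronger inhibitor, a higher number a weaker inhibitor:
- compound 1 `COc1ccc([C@@H]2[C@H](Oc3ccccc3)C(=O)N2c2cc(OC)c(OC)c(OC)c2)cc1OC` gives 26000 nM
- compound 2 `COc1cc(N2C(=O)[C@@H](Oc3ccccc3)[C@H]2c2ccc(Br)cc2)cc(OC)c1OC` gives 48000 nM
- compound 3 `COc1cc(N2C(=O)[C@@H](Oc3ccccc3)[C@H]2c2ccc(C#N)cc2)cc(OC)c1OC` gives 31600 nM

Compound 3 at 31600 nM cannot be separated from either of the other two, since all three numbers lie within the scatter of one another. The move from compound 3 to compound 4 `COc1cc(N2C(=O)[C@@H](Oc3ccccc3)[C@H]2c2cccc3ccccc23)cc(OC)c1OC` is naphthalen-1-yl in place of 4-cyanophenyl on a saturated ring carbon and amounts to naphthalen-1-yl in place of 4-cyanophenyl on a saturated ring carbon.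

The measured steps that bear on this move all vary the aromatic group at that same carbon. They are a 1.8-fold higher number from compound 1 to compound 2 (0.27 log units; within the scatter) and a 1.2-fold higher number from compound 1 to compound 3 (0.08 log units; within the scatter) and also a 1.5-fold lower number from compound 2 to compound 3 (0.18 log units; within the scatter) and none of them leaves the scatter. Across these three compounds, the group at that carbon has so far shown no measurable influence on the number. Among the compounds with values here, no measured compound carries a naphthalen-1-yl group, however, so the range has to stay wider than those steps alone would suggest.

No step beyond the scatter is expected in either direction, and the estimated change is a 1.1-fold lower number from compound 3 to compound 4 (0.02 log units; within the scatter) in this assay on this reasoning. The estimate for compound 4 is 30000 nM with an expected range from 12000 nM to 70000 nM for the measurement to come.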

Compound 4, half-maximal inhibitory concentration: 53000 nM
Estimate against measurement, compound 4: 1.8-fold (0.25 log units) below, within the range that was stated.
By their numbers in this assay, from the lowest: compounds 1, 3, 2 and 4 (each within the scatter of the next, the first and the last beyond it).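

In this assay the saturated ring carbon next to the ring nitrogen now gives its first step beyond the scatter, a 2.0-fold higher number from compound 1 to compound 4 (0.31 log units; beyond the scatter) and a modest one, so the aromatic group held there is not wholly without influence on the number. That separation holds only against 3,4-dimethoxyphenyl, since naphthalen-1-yl stays within the scatter of the other two groups, with a 1.7-fold higher number from compound 3 to compound 4 (0.22 log units; within the scatter) for 4-cyanophenyl and a 1.1-fold higher number from compound 2 to compound 4 (0.04 log units; within the scatter) for 4-bromophenyl. Two aromatic rings at this carbon therefore cannot be told from either of those single rings here, and no measurement at hand speaks to why compound 1 and compound 4 separate.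

The compounds shown leave open whether anything other than an all-carbon aromatic ring at this carbon, such as a pyridine ring, a cyclohexyl group or a phenyl ring carrying a carboxylic acid or an amine, would move the number out of this narrow spread. They also leave open what happens at the ring atom that bears a phenoxy group, where a hydroxy or amino group in place of phenoxy would test a part of the shared core that has stayed the same throughout.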